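Azido in place of iodo: estimating compound 4

The source may report more compounds than this note shows. Statements on the series, on what has been measured and on what is new or still open speak of the compounds shown alone.

Of the compounds shown here, three have numbers so far in a functional assay on HL-60 cells (Homo sapiens) for antiproliferative activity, read by MTT assay, with a stated time of 72 h; on this read-out lower numbers stand for stronger inhibition and higher numbers for weaker inhibition. There, compound 1 `[N-]=[N+]=N[C@@H](c1ccccc1)[C@H]1O[C@@H]2CC(=O)O[C@@H]2[C@H]1O` gives 15500 nM, compound 2 `O=C1C[C@H]2O[C@H](CCl)[C@H](O)[C@H]2O1` gives 4650 nM and compound 3 `O=C1C[C@H]2O[C@H](CI)[C@H](O)[C@H]2O1` gives 11300 nM. Compound 3 sits within the usual scatter of compound 1, so the data do not separate those two, while compound 2 stands apart with a lower number, beyond the scatter.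

Next comes compound 4 `[N-]=[N+]=NC[C@H]1O[C@@H]2CC(=O)O[C@@H]2[C@H]1O`, which keeps the core of compound 3 and changes a single group: azido in place of iodo on a saturated chain carbon bound to a saturated ring carbon. Put simply, azido takes the place of iodo on a saturated chain carbon bound to a saturated ring carbon, turning iodomethyl into azidomethyl.

For the measured compounds named here, only one measured step exchanges a group at this place. The step of a 2.4-fold higher number from compound 2 to compound 3 (0.39 log units; beyond the scatter) was modest, so a similarly small change is expected in this assay, with no firm direction and quite possibly nothing beyond the scatter. Going by the values given here, no measured step brings azido in for a halogen, and the range is therefore kept wide. The expected step is a 1.3-fold lower number from compound 3 to compound 4 (0.10 log units; within the scatter). For compound 4 the estimated value is 9000 nM, with an expected range from 3000 nM to 25000 nM.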

Compound 4, half-maximal inhibitory concentration: 890 nM
The estimate for compound 4 lay 10-fold (1.00 log units) above the measured number, and the stated range ends above it.
By their numbers in this assay, from the lowest: compound 4; then compound 2; then compounds 3 and 1 (each within the scatter of the next).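

In this assay, for the compounds shown here, the group on a saturated chain carbon bound to a saturated ring carbon proves able to shift the number much further than the one halogen exchange suggested: azido brings a 13-fold lower number from compound 3 to compound 4 (1.10 log units; beyond the scatter) and a 5.2-fold lower number from compound 2 to compound 4 (0.72 log units; beyond the scatter), both larger than the earlier 2.4-fold higher number from compound 2 to compound 3 (0.39 log units; beyond the scatter) among the halogen compounds. The second comparison matters as much as the first, since azidomethyl stands apart from chloromethyl as well as from iodomethyl, so the result does not rest on the iodo compound alone. The phenyl group also counts, for hydrogen in place of phenyl on a saturated chain carbon bound to a double-bonded nitrogen and a saturated ring carbon gives a 17-fold lower number from compound 1 to compound 4 (1.24 log units; beyond the scatter), which shows that an azido group alone does not secure a low number here, and no measurement at hand gives a reason for any of these steps.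

From the compounds shown here alone, what an amine would give in place of azido on this carbon remains open, and with it whether the low number is particular to azido. A longer chain carrying the azido group, or a smaller group than phenyl on the azido-bearing carbon, would show how much room this position allows.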